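The source may report more compounds than this note shows. Statements on the series, on what has been measured and on what is new or still open speak of the compounds shown alone.

Working notes on the series

Of the compounds shown here, three have so far been measured in a functional assay on the whole organism for inhibition, with Mus musculus as the target, at a dose of 1 mg/kg by the oral route; a higher number here means more inhibition at the dose given (going by the name of the read-out), a lower number less inhibition. Compound 1 `CCN(C(=O)c1c(O)c2c(F)cccc2n(C)c1=O)c1ccccc1` gives 60% in this assay, compound 2 `CC(C)N(C(=O)c1c(O)c2c(Cl)cccc2n(C)c1=O)c1ccccc1` gives 54%, and compound 3 `COc1cccc2c1c(O)c(C(=O)N(C)c1c(F)cccc1F)c(=O)n2C` gives 43%. Compound 3 stands lowest of the three: the nearest number is that of compound 2, the furthest that of compound 1, and both gaps lie beyond the usual scatter of this assay. Compounds 1 and 2 each differ from compound 3 in more than one place, so no single change within the measured set can be followed on its own.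

Compound 4 `COc1cccc2c1c(O)c(C(=O)N(C)c1cccc(Cl)c1)c(=O)n2C` has not been measured. It differs from compound 3 in one place: 3-chlorophenyl in place of 2,6-difluorophenyl on an amide-type nitrogen. With no comparable single change among the measured compounds, only a cautious expectation can be given. The step is estimated at a number 7 percentage points higher from compound 3 to compound 4 (within the scatter), a rise that may not exceed the scatter. Compound 4 is expected to give 50% in this assay, within a range of 30% to 70%.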

Compound 4, a percentage reported as inhibition, in the whole organism at one dose (the size of the read-out at that dose, not a potency): 85%
The estimate for compound 4 lay 35 percentage points below the measured number, and the stated range ends below it.
By their numbers in this assay, from the lowest: compound 3; then compounds 2 and 1 (each within the scatter of the next); then compound 4.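

On the amide-type nitrogen whose other neighbours are a carbonyl carbon and a saturated chain carbon, the aryl group has a strong hold on this assay, and 3-chlorophenyl in place of 2,6-difluorophenyl gives a number 42 percentage points higher from compound 3 to compound 4 (beyond the scatter). Among these compounds, this is the first change that can be followed on its own, and it shows that this one place can move the read-out well beyond the scatter while the rest of compound 3 stays unchanged. Nothing at hand bears on the reason for this step.

Going by these compounds, whether the rise belongs to the chlorine, to its place on the ring or to the loss of the two fluorines stays open, and 3-fluorophenyl or 2-chlorophenyl on the same nitrogen would help separate these readings. Also open, on these data alone, is whether 3-chlorophenyl would have a comparable effect on the cores of compound 1 and compound 2.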